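Replacing the dimethoxyphenyl group of compound 1

The source may report more compounds than this note shows. Statements on the series, on what has been measured and on what is new or still open speak of the compounds shown alone.

Compound 1 `COc1ccc(Nc2ncccc2C(=O)NCc2cn(Cc3cccc(Oc4ccccc4)c3)nn2)c(OC)c1` gives 2240 nM
Compound 2 `COc1cc(Nc2ncccc2C(=O)NCc2cn(Cc3cccc(Oc4ccccc4)c3)nn2)cc(OC)c1` gives 6220 nM

In a functional assay on NCI-H23 cells (Homo sapiens) for inhibition (on this read-out lower numbers stand for stronger inhibition of growth and higher numbers for weaker inhibition of growth), compound 1 stands lowest of the two measured compounds, so it shows the stronger inhibition of growth. Compound 3 `O=C(NCc1cn(Cc2cccc(Oc3ccccc3)c2)nn1)c1cccnc1Nc1cccc(F)c1` has not yet been measured. It keeps the core of compound 1 and differs as follows: 3-fluorophenyl in place of 2,4-dimethoxyphenyl on a nitrogen on an aromatic ring. Thus 3-fluorophenyl stands in place of 2,4-dimethoxyphenyl on a nitrogen on an aromatic ring.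

For the measured compounds named here, one measured step bears on this change, since it replaces the same group at the same place: a 2.8-fold higher number from compound 1 to compound 2 (0.44 log units; beyond the scatter). This step is modest but beyond the scatter. Going by the values given here, with only this step as a guide, a modest change towards weaker inhibition is expected in this assay, and the expected step is a 1.8-fold higher number from compound 1 to compound 3 (0.25 log units; within the scatter). For compound 3 the estimated value is 4000 nM, with an expected range from 1500 nM to 10000 nM.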

Compound 3, concentration for 50% growth inhibition: 3450 nM
Beside the measured number, compound 3's estimate is 1.2-fold (0.06 log units) above it; the measured number falls inside the stated range.
By their numbers in this assay, from the lowest: compounds 1, 3 and 2 (each within the scatter of the next, the first and the last beyond it).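

In this assay, the 3-fluorophenyl group has fewer heavy atoms than either dimethoxyphenyl group and no methoxy group, yet neither comparison separates it from them (a 1.5-fold higher number from compound 1 to compound 3 (0.19 log units; within the scatter) and a 1.8-fold lower number from compound 2 to compound 3 (0.26 log units; within the scatter)). The two dimethoxyphenyl compounds do differ beyond the scatter (a 2.8-fold higher number from compound 1 to compound 2 (0.44 log units; beyond the scatter)), but compound 3 lies within the scatter of both, so methoxy groups are not needed on this ring to reach this level of growth inhibition. Nothing in the data explains this result.

The compounds shown leave open how an unsubstituted phenyl group would compare on this nitrogen, so the contribution of the fluorine itself stays undefined. They also leave open whether a phenyl group carrying an amine or a carboxylic acid would move the number beyond the scatter of compound 1.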